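The compounds below may be only part of what the source reports. "The series", "measured", "known", "first", "only" and "open" are said of these compounds alone.

Compound 1 `CCCCCCCNC[C@@H]1OC[C@H](N)[C@H]1O`: > 128000 nM
Compound 2 `CCCCCCCCCCNC[C@@H]1OC[C@H](N)[C@H]1O`: > 128000 nM
Compound 3 `CCCCCCCCCNC[C@@H]1OC[C@H](N)[C@H]1O`: > 128000 nM

All three share one core, an aminotetrahydrofuranol carrying a secondary amine whose other substituent is a straight alkyl chain, and all three were tested in a functional assay on A549 cells (Homo sapiens) for antiproliferative activity, read by MTT assay, with a stated time of 72 h; on this read-out higher numbers stand for weaker inhibition and lower numbers for stronger inhibition. Every number above is a limit of this assay, not a measured value. Compound 3 therefore stands at a limit, > 128000 nM, and the same is true of compound 1 and of compound 2, as summarised by the limit of > 128000 nM in this assay, at which 3 of the 3 values shown sit. For that reason none of the three steps among them can be read: a step that the two limits leave unreadable from compound 1 to compound 2, a step that the two limits leave unreadable from compound 1 to compound 3 and a step that the two limits leave unreadable from compound 2 to compound 3 are all hidden by the limits.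

Compound 4 `CCCCCCCCCCCCCCNC[C@@H]1OC[C@H](N)[C@H]1O` has not yet been tested in this assay. It differs from compound 3 by pentyl in place of hydrogen on a saturated chain carbon, nine bonds along the chain from an amine nitrogen. The measured steps that bear on this chain lengthening, those among compounds 1, 2 and 3, give no size and no direction, so there is nothing to project a step from. The most conservative expectation is that compound 4 stays near the limit as well, with an estimated step of an at least 1.2-fold lower number from compound 3 to compound 4 (0.10 log units; that floor lies within the scatter) in this assay. Compound 4 is thus estimated at 100000 nM, within a range from 20000 nM to 300000 nM.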

Compound 4, half-maximal inhibitory concentration: 20000 nM
For compound 4 the middle estimate is 5.0-fold (0.70 log units) above the measured one; the measured number falls inside the stated range.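

Chain length at this place does change the read-out in this assay, which the earlier compounds could not show: pentyl in place of hydrogen on a saturated chain carbon, nine bonds along the chain from an amine nitrogen, gives an at least 6.4-fold lower number from compound 3 to compound 4 (0.80 log units; beyond the scatter). Measured against the two other chains, the result is an at least 6.4-fold lower number from compound 2 to compound 4 (0.80 log units; beyond the scatter) and an at least 6.4-fold lower number from compound 1 to compound 4 (0.80 log units; beyond the scatter), so all three new steps point the same way and each is a minimum rather than an exact size. Compound 4 is the only one of the four with a measured number, while the other three remain at a limit: the limit of > 128000 nM in this assay, at which 3 of the 4 values shown sit.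

The steps among compound 1, compound 2 and compound 3 cannot be read, so the compounds shown do not tell at which chain length the read-out first leaves the limit. Also open, on these data alone, is whether a longer chain than that of compound 4 would lower the number further, and whether a branched chain, an ether oxygen within the chain or a tertiary amine in place of the secondary amine would keep this step.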